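The compounds below may be only part of what the source reports. "The series", "measured", "known", "first", "only" and "open" are said of these compounds alone.

Working notes on a small set of hydroxylated pyrrolidines tested in an assay on isolated protein for inhibition of lysosomal alpha-glucosidase (Rattus norvegicus), read by colorimetric assay; a lower number here means a stronger inhibitor, a higher number a weaker inhibitor.

Compound 1, `OC[C@]1(c2ccccc2)NC[C@H](O)[C@H]1O`, gives 190 nM in this assay. Compound 2, `COc1ccc([C@]2(CO)NC[C@@H](O)[C@@H]2O)cc1`, carries a methoxyphenyl in place of the phenyl of compound 1. In this assay compound 2 gives 395000 nM. On the two numbers available, compound 2 stands highest, and its gap to compound 1 lies far beyond the scatter.

Compound 3, `COc1ccc([C@@]2(CO)NC[C@H](O)[C@H]2O)cc1`, is the not yet measured partner of compound 2. The change is the two compounds have the same atoms and bonds and differ only in configuration as drawn: 3 of 3 stereo elements differ (all stereocentres are inverted: mirror images); a stereocentre at a saturated ring carbon is drawn R in compound 2 and S in compound 3; a stereocentre at a saturated ring carbon is drawn R in compound 2 and S in compound 3; a stereocentre at a saturated ring carbon is drawn R in compound 2 and S in compound 3. In other words, nothing is added or removed; every stereocentre on the saturated ring is inverted, and compound 3 is the mirror image of compound 2.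

Within the data shown here, no measured pair in this set shows the effect of inverting all centres, so the size of the step in this assay must be inferred. Compound 2 at 395000 nM is very weak, while compound 1 at 190 nM shows that a closely related aryl-substituted core of this type can be strongly inhibiting, which suggests compound 2 may be the wrong-handed form. The step from compound 2 to compound 3 is therefore expected to be large and downward, a 790-fold lower number from compound 2 to compound 3 (2.90 log units; beyond the scatter). Compound 3 is estimated at 500 nM, with a range from 100 nM to 5000 nM.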

Compound 3, half-maximal inhibitory concentration: 2100 nM
Beside the measured number, compound 3's estimate is 4.2-fold (0.62 log units) below it; measured number inside the range.
By their numbers in this assay, from the lowest: compound 1; then compound 3; then compound 2.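

In this assay, inverting every stereocentre gives a 190-fold lower number from compound 2 to compound 3 (2.27 log units; beyond the scatter), so the handedness of the shared core matters on its own, with no atom added or removed. The step between these mirror images can be assigned to configuration alone because of a single fact: the fact that compounds 2 and 3 differ only in the configuration as drawn. The series also now has its first reading of the methoxy group, where methoxy in place of hydrogen on an aromatic carbon gives an 11-fold higher number from compound 1 to compound 3 (1.04 log units; beyond the scatter), a step beyond the scatter but smaller than the step from inversion.

The compounds shown leave open whether one stereocentre or several account for the inversion step, since all of them change together in this pair, and how the mirror image of compound 1 would read. As far as these compounds go, it also remains open whether the step from the methoxy group is particular to that group or would recur with another aromatic substituent such as a fluorine atom, a hydroxyl group or an amine, or with a carboxylic acid in place of the hydroxymethyl group.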